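The compounds below may be only part of what the source reports. "The series", "measured", "known", "first", "only" and "open" are said of these compounds alone.

Working notes, series in an ADME assay on MRC5 cells (Homo sapiens) for inhibition, with a stated time of 72 h; a higher number here means that more compound is needed for the effect, a lower number that less compound is needed:

- compound 1 `COc1cccc(OC)c1C(=O)Nc1c[nH]nc1C(=O)Nc1ccncc1`: > 50000 nM
- compound 2 `CO[C@H]1CC[C@H](NC(=O)c2n[nH]cc2NC(=O)c2ncoc2-c2ccccc2)CC1`: 28000 nM
- compound 3 `COc1cc(OC)c(C(=O)Nc2c[nH]nc2C(=O)N[C@H]2CC[C@H](OC)CC2)c(OC)c1`: > 50000 nM

Compound 1 stands at a limit of the assay in this assay, so for compound 1 there is no number, only the statement that the measured value lies past the limit. Compound 3 likewise shows only a limit of the assay, not a number. Among the compounds with values here, compound 2 is the single compound with a number in this assay, and that number is itself high. Taken together, the limit of > 50000 nM in this assay, at which 2 of the 3 values shown sit, is where most of the series sits, and nothing measured so far separates the compounds from one another beyond that.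

Compound 4 `CCCCCNC(=O)c1n[nH]cc1NC(=O)c1c(OC)cccc1OC` differs from compound 1 in one place: pentyl in place of pyridin-4-yl on an amide-type nitrogen. Within the data shown here, no pair of measured compounds carries this same change, so there is no measured step to lean on; what is known of compound 1 is only its limit.

With compound 1 at a limit and nothing in the series pointing in either direction, no step beyond the usual scatter is expected here, and compound 4 is estimated to stay near the limit as well, as an at least 1.2-fold lower number from compound 1 to compound 4 (0.09 log units; that floor lies within the scatter) expresses. The expected value for compound 4 is 40000 nM, with a range from 12000 nM to 50000 nM, and a real chance that the assay again reports only a limit.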

Compound 4, half-maximal effective concentration: > 50000 nM
Compound 4: only a limit was reported; the forecaster's own chance of this, stated with the estimate: 55%; middle value at least 1.2-fold (0.09 log units) away from the limit.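

In this assay compound 4 gives > 50000 nM as a limit of the assay and not a number. Compound 1 also stands at a limit, so the step between compound 1 and compound 4 cannot be read. The compounds shown leave open how those at the limit differ from one another, as most of the series sits at one limit: the limit of > 50000 nM in this assay, at which 3 of the 4 values shown sit.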